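This account rests on a few compounds, and the source may have more. Where it says the series, first, only, none or still open, it means among the compounds named here.

Measured compounds in a functional assay on TK-10 cells (Homo sapiens) for inhibition, read by sulforhodamine B assay, with a stated time of 48 h; a higher number here means a weaker inhibitor of growth, a lower number a stronger inhibitor of growth:

Compound 1 `COc1cc(-c2cc(/C=C/C(=O)c3ccc(N)cc3)[nH]n2)cc(OC)c1OC`: 17500 nM
Compound 2 `COc1cc(-c2cc(/C=C/C(=O)c3ccc(Cl)c(Cl)c3)[nH]n2)cc(OC)c1OC`: 43200 nM
Compound 3 `COc1ccc(C(=O)/C=C/c2cc(-c3cc(OC)c(OC)c(OC)c3)n[nH]2)cc1`: 5770 nM

Compound 3 stands lowest of the three numbers in this assay; the nearest to it is compound 1, which sits higher by a 3.0-fold lower number from compound 1 to compound 3 (0.48 log units; beyond the scatter) read the other way, and the furthest is compound 2, separated by a 7.5-fold lower number from compound 2 to compound 3 (0.87 log units; beyond the scatter). Both of these steps alter the aryl group on the carbonyl carbon, and both were modest in size.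

Compound 4 `COc1ccc(C(=O)/C=C/c2cc(-c3cc(OC)c(OC)c(OC)c3)n[nH]2)cc1OC` differs from compound 3 by methoxy in place of hydrogen on an aromatic carbon. Within the data shown here, no measured step adds a methoxy in place of a hydrogen, so the comparison is only indirect: the two steps that touch this same ring, a 3.0-fold lower number from compound 1 to compound 3 (0.48 log units; beyond the scatter) and a 7.5-fold lower number from compound 2 to compound 3 (0.87 log units; beyond the scatter), show that changing the groups on it shifts the number by modest amounts in this assay, and a second methoxy is a smaller change than either of those. The expected step is therefore small, a 1.1-fold higher number from compound 3 to compound 4 (0.05 log units; within the scatter), with no clear direction beyond the scatter. Compound 4 is estimated at 6500 nM in this assay, within a range from 2500 nM to 17000 nM.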

Compound 4, concentration for total growth inhibition: 2600 nM
The estimate for compound 4 lay 2.5-fold (0.40 log units) above the measured number; low and high end bracket the measured number.
By their numbers in this assay, from the lowest: compound 4; then compound 3; then compound 1; then compound 2.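

In this assay, among these compounds, the step of a 2.2-fold lower number from compound 3 to compound 4 (0.35 log units; beyond the scatter) gives the first direct reading of methoxy in place of hydrogen on this ring: going from 4-methoxyphenyl to 3,4-dimethoxyphenyl lowers the number by a modest amount, beyond the scatter. The 3,4-dimethoxyphenyl group also stands well apart from the other aryl groups on the carbonyl carbon, with a 17-fold lower number from compound 2 to compound 4 (1.22 log units; beyond the scatter) and a 6.7-fold lower number from compound 1 to compound 4 (0.83 log units; beyond the scatter), and its steps to all three other compounds place compound 4 lowest of the four. Nothing given here explains these differences.

The compounds shown leave open whether a hydroxy or ethoxy group on this same aromatic carbon would give a similar step. They also leave open whether this methoxy would lower the number without the methoxy group it stands ortho to.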